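Amide side chain swap from compound 3 to compound 4

This account rests on a few compounds, and the source may have more. Where it says the series, first, only, none or still open, it means among the compounds named here.

Measured in a functional assay on HepG2 cells (Homo sapiens), read by MTT assay, with a stated time of 48 h; a higher number here means a weaker inhibitor, a lower number a stronger inhibitor:
- compound 1 `CCN(CC)CCCNC(=O)c1ccc(C(CC)(CC)c2ccc(OCC(=O)C(C)(C)C)c(C)c2)n1CC`: 180 nM
- compound 2 `CCn1c(C(=O)NCCN)ccc1C(CC)(CC)c1ccc(OCC(=O)C(C)(C)C)c(C)c1`: 180 nM
- compound 3 `CCN(CC)CCCNC(=O)c1ccc(C(CC)(CC)c2ccc(OCC(O)C(C)(C)C)c(C)c2)n1CC`: 1100 nM

Of the three, compound 3 carries the highest number, 1100 nM, and so reads as the weakest inhibitor. Compound 1 and compound 2 show the same value.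

The next compound is compound 4 `CCn1c(C(=O)N(CCC#N)CCC#N)ccc1C(CC)(CC)c1ccc(OCC(O)C(C)(C)C)c(C)c1`, which keeps the hydroxyl-bearing side of compound 3 and changes the amide side chain: a group of 9 heavy atoms (6 carbon, 3 nitrogen; no ring) in place of a group of 9 heavy atoms (7 carbon, 2 nitrogen; no ring), on a carbonyl carbon. The change sits on a carbonyl carbon.

Two measured steps are available. The closer one falls on the same side chain: no change at the digits printed from compound 1 to compound 2 (within the scatter). It offers only limited guidance, since compound 1 and compound 2 both keep the amide hydrogen and an amino group on the chain, and compound 4 has neither. The other step lies elsewhere in the molecule and is modest: a 6.1-fold higher number from compound 1 to compound 3 (0.79 log units; beyond the scatter). It shows only how far one change has moved the number in this series. Among the measured compounds shown here, no measured compound lacks the amide hydrogen, so the direction is uncertain. A modest loss is the expected outcome, and a result within the scatter remains possible.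

The expected change is a 2.5-fold higher number from compound 3 to compound 4 (0.41 log units; beyond the scatter). For compound 4 the estimated value is 2800 nM, with an expected range of 900 nM to 9000 nM.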

Compound 4, half-maximal inhibitory concentration: 42000 nM
Estimate against measurement, compound 4: 15-fold (1.18 log units) below, outside the stated range (above it).
By their numbers in this assay, from the lowest: compounds 1 and 2 (each within the scatter of the next); then compound 3; then compound 4.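

The amide side chain on the carbonyl carbon proves far from indifferent: in this assay, the exchange gives a 38-fold higher number from compound 3 to compound 4 (1.58 log units; beyond the scatter), a larger step than the hydroxyl change on the other side of the molecule, a 6.1-fold higher number from compound 1 to compound 3 (0.79 log units; beyond the scatter). The calm seen in no change at the digits printed from compound 1 to compound 2 (within the scatter) therefore does not extend to every group here, although that step kept the amide hydrogen and an amino group, and the entering group in compound 4 has neither, with 0 hydrogen-bond donors and 2 triple bonds outside aromatic rings. No available measurement assigns this loss to any one feature of the entering group.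

The result leaves unresolved whether the amide hydrogen, the amine or the added triple bonds account for the step, since all three change together in compound 4; a secondary amide carrying a single 2-cyanoethyl chain, or a methyl on the amide nitrogen with the (3-(diethylamino)propyl) chain kept, would separate them. Also open, on these data alone, is whether the same side chain exchange would cost as much with the (tert-butyl)carbonyl group of compound 1 in place of the hydroxyl-bearing side.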